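The source may report more compounds than this note shows. Statements on the series, on what has been measured and on what is new or still open speak of the compounds shown alone.

Measured so far in a functional assay on NAMALVA cells (Homo sapiens) for cytotoxicity, read by MTT assay, with a stated time of 72 h; a higher number here means a weaker inhibitor, a lower number a stronger inhibitor

compound 1 `COc1ccc(NC(=O)Nc2ccc(C(=O)NO)cc2)cc1` at 4790 nM
compound 2 `COc1ccc(NC(=O)Nc2ccc(/C=C/C(=O)NO)cc2)cc1` at 460 nM
compound 3 `O=C(CCc1ccc(NC(=O)Nc2ccc(Cl)cc2)cc1)NO` at 370 nM

Compound 3 lies within the scatter of compound 2, and both lie well beyond the scatter of compound 1, which has the higher number. Compound 4 `COc1ccc(NC(=O)Nc2ccc(CCC(=O)NO)cc2)cc1` differs from compound 3 by methoxy in place of chloro on an aromatic carbon, para to a large group methoxy in place of chloro on an aromatic carbon and nothing else. For the measured compounds named here, the one measured step, large at a 10-fold lower number from compound 1 to compound 2 (1.02 log units; beyond the scatter) for 2-(hydroxycarbamoyl)ethenyl in place of hydroxycarbamoyl, lies elsewhere in the structure. Going by the values given here, no measured step exchanges chloro for methoxy, so no step beyond the scatter is expected in this assay here. The estimate is a 1.2-fold higher number from compound 3 to compound 4 (0.09 log units; within the scatter) in this read-out. Compound 4 is expected at 450 nM with 180 nM to 1100 nM as its range.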

Compound 4, half-maximal inhibitory concentration: 1990 nM
Compound 4: the middle estimate sits 4.4-fold (0.65 log units) below what was measured; the whole stated range lies below it.
By their numbers in this assay, from the lowest: compounds 3 and 2 (each within the scatter of the next); then compound 4; then compound 1.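

In this assay, the exchange of 4-chlorophenyl for 4-methoxyphenyl is not neutral: on an aromatic carbon para to a large group, methoxy in place of chloro gives a clear loss (a 5.4-fold higher number from compound 3 to compound 4 (0.73 log units; beyond the scatter)). With methoxy held, the chain matters too, since 2-(hydroxycarbamoyl)ethyl falls behind 2-(hydroxycarbamoyl)ethenyl (a 4.3-fold higher number from compound 2 to compound 4 (0.64 log units; beyond the scatter)) yet still improves on hydroxycarbamoyl (a 2.4-fold lower number from compound 1 to compound 4 (0.38 log units; beyond the scatter)). No measurement at hand accounts for the difference between chloro and methoxy. From the compounds shown here alone, whether an amine at that position would track chloro or methoxy stays open, as does whether a longer chain would change either step.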